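A Methyl Added to a Chemokine Receptor Antagonist

The compounds below may be only part of what the source reports. "The series", "measured", "known", "first", "only" and "open" are said of these compounds alone.

Compound 1 `CC(C)(C)c1ccc(S(=O)(=O)Nc2ccc(Cl)cc2-c2nccc(C(N)=O)c2O)cc1`: 52 nM
Compound 2 `CC(C)(C)c1ccc(S(=O)(=O)Nc2ccc(Cl)cc2-c2nccnc2NCCO)cc1`: 34 nM

In a functional assay on isolated protein for antagonist activity at C-C chemokine receptor type 9 (Homo sapiens), read by calcium flux, with a stated time of 10 min (a lower number here means a stronger inhibitor, a higher number a weaker inhibitor), compound 1 gives 52 nM and compound 2 gives 34 nM. For the measured compounds named here, the one measured step is a 1.5-fold lower number from compound 1 to compound 2 (0.18 log units; within the scatter), so compound 2 stands level with compound 1 within the scatter. Compound 3 `Cc1cnc(-c2cc(Cl)ccc2NS(=O)(=O)c2ccc(C(C)(C)C)cc2)c(NCCO)n1` has not been measured; it differs from compound 2 by methyl in place of hydrogen on an aromatic carbon. Going by the values given here, no measured step adds a methyl, and the known step swapped a whole ring, so it bears little on this change. A shift of about a 1.1-fold lower number from compound 2 to compound 3 (0.05 log units; within the scatter) is therefore expected, in neither direction beyond the scatter. Compound 3 is estimated at 30 nM, within 10 nM to 90 nM.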

Compound 3, half-maximal inhibitory concentration: 268 nM
Beside the measured number, compound 3's estimate is 8.9-fold (0.95 log units) below it; measured number outside the range, above it.
By their numbers in this assay, from the lowest: compounds 2 and 1 (each within the scatter of the next); then compound 3.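

In this assay, methyl in place of hydrogen on this aromatic carbon, next to the ring nitrogen and para to a large group, gives a 7.9-fold higher number from compound 2 to compound 3 (0.90 log units; beyond the scatter). The earlier step swapped a whole ring and stayed within the scatter, whereas here a single added carbon moves the number well beyond it, so this position is sensitive to even the smallest carbon group. Nothing measured here explains the loss.

Going by these compounds, whether a fluorine, a chlorine or a methoxy group on this carbon would cost as much remains open. So does whether a longer chain in place of the (2-hydroxyethyl)amino group would change the effect of the methyl.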